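The source may hold more compounds than are shown below. What is called first, only, known or untested is meant among the compounds shown, and "the series" means these compounds.

Compounds measured so far:
- compound 1, `COc1cc(-c2cc3cc(C4C(C#N)=C(N)OC5=C4C(=O)CCC5)cc(C)c3oc2=O)cc(OC)c1OC`, gives 5.22% in a functional assay on the whole organism (strain Swiss albino) with Mus musculus as the target, in the forced swim test, with a stated time of 5 min, at a dose of 0.5 mg/kg by the intraperitoneal route; a higher number here means more inhibition at the dose given (going by the name of the read-out), a lower number less inhibition.
- compound 2, `COc1ccc(-c2cc3cc(C4C(C#N)=C(N)OC5=C4C(=O)CCC5)cc(C(C)(C)C)c3oc2=O)cc1`, gives 30.7% in this assay.
- compound 3, `COc1ccc(-c2cc3cc(C4C(C#N)=C(N)OC5=C4C(=O)CCC5)cc(C(C)(C)C)c3oc2=O)cc1OC`, gives -16.6% in this assay.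

Compound 3 holds the lowest of the three numbers. Its nearest neighbour is compound 1, and compound 2 stands furthest from it; both gaps lie beyond the usual scatter. Among the compounds with values here, the one single-point step among the measured compounds is the one from compound 2 to compound 3, a methoxy in place of hydrogen on an aromatic carbon, and it gave a number 47.3 percentage points lower from compound 2 to compound 3 (beyond the scatter).

Compound 4, `COc1cc(-c2cc3cc(C4C(C#N)=C(N)OC5=C4C(=O)CCC5)cc(C(C)(C)C)c3oc2=O)cc(OC)c1OC`, has not yet been measured. It differs from compound 3 in one place: methoxy in place of hydrogen on an aromatic carbon. Within the data shown here, the step from compound 2 to compound 3 is the only measured step of the same kind, and it was large and downward. Compound 4 will carry the 3,4,5-trimethoxyphenyl group that compound 1 already carries, and compound 1 gives 5.22%, which is above compound 3. Weighing these two pointers against each other, the account expects for compound 4 a value near -5%, within a range from -30% to 20%. The expected step from compound 3 to compound 4 is therefore a number 11.6 percentage points higher from compound 3 to compound 4 (beyond the scatter), a change that is estimated not to reach beyond the scatter.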

Compound 4, a percentage reported as inhibition, in the whole organism at one dose (the size of the read-out at that dose, not a potency): 5.33%
Beside the measured number, compound 4's estimate is 10.3 percentage points below it; low and high end bracket the measured number.
By their numbers in this assay, from the lowest: compound 3; then compounds 1 and 4 (each within the scatter of the next); then compound 2.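

In this assay the third methoxy reverses the direction seen for the same replacement on this ring: a number 21.9 percentage points higher from compound 3 to compound 4 (beyond the scatter) stands against a number 47.3 percentage points lower from compound 2 to compound 3 (beyond the scatter), so at these compounds the sign of this change depends on which aromatic carbon receives the methoxy and on the methoxy groups already present. The recovery is only partial, since 3,4,5-trimethoxyphenyl in place of 4-methoxyphenyl still gives a number 25.4 percentage points lower from compound 2 to compound 4 (beyond the scatter), and with the 3,4,5-trimethoxyphenyl group in place, tert-butyl in place of methyl gives a number 0.1 percentage points higher from compound 1 to compound 4 (within the scatter), so that swap leaves no readable mark on the number in this pair. Nothing at hand accounts for the reversal between the two methoxy steps.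

The compounds shown leave open whether a hydroxy, an ethoxy or a dimethylamino group on this aromatic carbon would follow the methoxy result. They also leave open whether tert-butyl in place of methyl would be just as silent with a 4-methoxyphenyl or 3,4-dimethoxyphenyl group, and how any of these numbers would shift at another dose.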